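Ring-amine methylation in a bridged nicotinic agonist series

A few compounds are considered here, and "the series" means these few. Any claim that something is new, unique, unknown or untested is made for them only; others in the source may bear on it.

Measured so far in an in vitro functional assay on SH-SY5Y cells for agonist activity at Neuronal acetylcholine receptor; alpha3/beta4 (Homo sapiens), read by FLIPR and calcium flux; on this read-out lower numbers stand for smaller maximal responses and higher numbers for larger maximal responses:
compound 1 `CN1C[C@H]2C=C(c3cccnc3)C[C@H](C2)C1`, 31%
compound 2 `Fc1ccc(C2=CC3CNCC(C2)C3)cn1`, 140%
compound 3 `CC(C)Oc1cncc(C2=CC3CNCC(C2)C3)c1`, 160%

Compound 3 stands highest of the three numbers. Its nearest neighbour is compound 2, whose value lies lower by a margin beyond the usual scatter; furthest away is compound 1, whose value is far lower, again beyond the scatter. Within the data shown here, no pair of measured compounds differs in a single place, so no step between them can be stated.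

Compound 4 `CC(C)Oc1cncc(C2=CC3CC(C2)CN(C)C3)c1` is the next compound to be measured. It differs from compound 3 by methyl in place of hydrogen on an amine nitrogen in a ring. Among the measured compounds shown here, compound 1 is the only measured compound carrying a methyl on that ring nitrogen, and in this assay compound 1 gives 31%, the lowest number of the set, but it also lacks the isopropoxy group, so the two values show only that such a methylated compound can sit far below the unmethylated ones.

For compound 4 the expected step of a number 105 percentage points lower from compound 3 to compound 4 (beyond the scatter) is a decrease well beyond the scatter. Compound 4 is estimated at 55%, with a range from 25% to 110%.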

Compound 4, largest response reached (reported as percent of maximum), in percent of the reference or control that the assay uses: 15%
For compound 4 the middle estimate is 40 percentage points above the measured one; the measured number lies below the stated range.
By their numbers in this assay, from the lowest: compound 4; then compound 1; then compound 2; then compound 3.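

In this assay, among these compounds, the change of methyl in place of hydrogen on an amine nitrogen in a ring gives a number 145 percentage points lower from compound 3 to compound 4 (beyond the scatter) and so stands as a single change, which the earlier compounds could not show, since compound 1 carries that methyl without the isopropoxy group. With the isopropoxy group held constant, the loss of maximal response goes with the methyl alone, and the isopropoxy group does not keep the response of compound 3 once the ring nitrogen bears methyl. Nothing measured here bears on the reason for a step of this size.

On these data alone, whether ethyl or an acetyl group on that ring nitrogen would give a response like that of compound 3 or that of compound 4 stays open. Also open, as far as these compounds go, is whether the same methyl change would give a step of similar size from compound 2, which keeps the hydrogen there.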